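Methoxy in place of hydrogen across two measured pairs

This account rests on a few compounds, and the source may have more. Where it says the series, first, only, none or still open, it means among the compounds named here.

Measured so far, in a functional assay on MCF7 cells (Homo sapiens) for inhibition, read by trypan blue exclusion, with a stated time of 72 h; a lower number here means a stronger inhibitor of growth, a higher number a weaker inhibitor of growth:
compound 1 `CC/C(=C(\c1ccccc1)c1ccc(NC(=O)C(C)C)cc1)c1ccc(OCc2ccccc2)cc1`: > 30000 nM, a limit of the assay
compound 2 `CC/C(=C(/c1ccc(NC(=O)C(C)C)cc1)c1ccc(OC)cc1)c1ccc(OCc2ccccc2)cc1`: 29000 nM
compound 3 `CC/C(=C(\c1ccccc1)c1ccc(NC(=O)C(C)C)cc1)c1ccc(Cl)cc1Cl`: 8300 nM

Compound 2 differs from compound 1 in one place: methoxy in place of hydrogen on an aromatic carbon. The step of an at least 1.0-fold lower number from compound 1 to compound 2 (0.01 log units; that floor lies within the scatter) rests on a limit of > 30000 nM in this assay, at which 1 of the 3 values shown sits, and so gives only a floor. Compound 3 holds the lowest of the two numbers read in this assay; how its core differs from the core of compound 1 is not broken down here. Compound 4 `CC/C(=C(/c1ccc(NC(=O)C(C)C)cc1)c1ccc(OC)cc1)c1ccc(Cl)cc1Cl` carries the same change on the core of compound 3: methoxy in place of hydrogen on an aromatic carbon. The place is the same in both pairs. The earlier step of an at least 1.0-fold lower number from compound 1 to compound 2 (0.01 log units; that floor lies within the scatter) lay within the scatter. For compound 4 a similarly small step is expected, a 1.2-fold lower number from compound 3 to compound 4 (0.07 log units; within the scatter). Compound 4 is therefore estimated at 7000 nM in this assay, between 2500 nM and 20000 nM.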

Compound 4, concentration for 50% growth inhibition: 6600 nM
Compound 4: middle estimate off by 1.1-fold (0.03 log units), on the high side, and the stated range covers the measured number.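

In this assay, the change from phenyl to 4-methoxyphenyl gives a 1.3-fold lower number from compound 3 to compound 4 (0.10 log units; within the scatter). Set beside the same change on the core of compound 1, the two steps cannot be told apart in size: the same change on two cores in this assay, an at least 1.0-fold lower number (0.01 log units; that floor lies within the scatter) from compound 1 to compound 2 and a 1.3-fold lower number (0.10 log units; within the scatter) from compound 3 to compound 4; the limit leaves it open whether they differ This shows a step within the scatter on the core of compound 3, but it does not show that the step carries over unchanged from one core to the other, as the pair on the core of compound 1 rests on a limit and its true size stays open: the limit of > 30000 nM in this assay, at which 1 of the 4 values shown sits.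

The compounds shown leave open whether an amine or a hydroxyl at the same place would move the number beyond the scatter. They also leave open whether a longer chain on the oxygen would do so.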